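A Bromine Added to a Small Two-Ring Amide

The source may report more compounds than this note shows. Statements on the series, on what has been measured and on what is new or still open speak of the compounds shown alone.

Compound 1 `O=C(Nc1cccnc1)c1cccnc1` is a small amide that joins two aromatic rings. Among the compounds with values here, in an assay on V79 cells for inhibition of cytochrome P450 11B2, mitochondrial (Homo sapiens), tested at 500 nM (a lower number here means less inhibition, a higher number more inhibition at the concentration tested (going by the name of the read-out)), compound 1 gives 8%, the lowest of the two numbers so far, while compound 2 `O=C(Nc1cccnc1)c1ccncc1` gives 39%, a gap beyond the usual scatter. Compound 3 `O=C(Nc1cccnc1)c1cncc(Br)c1` differs from compound 1 by a single change: bromo in place of hydrogen on an aromatic carbon. Within the data shown here, no step between two measured compounds shows what such a change does, so the step is expected to be modest and upward, a number 14 percentage points higher from compound 1 to compound 3 (beyond the scatter). Compound 3 is therefore estimated at 22%, with a range from 5% to 45%.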

Compound 3, a percentage reported as inhibition, at one concentration (the size of the read-out at that concentration, not a potency): 29%
Estimate against measurement, compound 3: 7 percentage points below, within the range that was stated.
By their numbers in this assay, from the lowest: compound 1; then compounds 3 and 2 (each within the scatter of the next).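

Bromo in place of hydrogen on an aromatic carbon, two atoms from the ring nitrogen, gives in this assay a number 21 percentage points higher from compound 1 to compound 3 (beyond the scatter) and so provides the first measured step at this position. A single bromine atom on the core of compound 1 is thus enough to change the read-out. Nothing shown here explains why the number rises.

On these data alone, it remains open whether chloro, methyl or an amine at the same place would give a similar number. One step also cannot show whether the same change would act alike on the core of compound 2.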